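A few compounds are considered here, and "the series" means these few. Any claim that something is new, unique, unknown or untested is made for them only; others in the source may bear on it.

Measured in an ADME assay on microsomes from liver (Mus musculus) for metabolic stability; on this read-out higher numbers stand for a longer-lived compound and lower numbers for a shorter-lived compound:
Compound 1 `NS(=O)(=O)CC(=O)NCCSc1nonc1/C(=N/O)Nc1cccc(C(F)F)c1`: 1.5 h
Compound 2 `CC1(C(=O)NCCSc2nonc2/C(=N/O)Nc2ccc(F)c(C(F)F)c2)CCN1`: 0.268 h
Compound 3 `O=C(NCCSc1nonc1/C(=N/O)Nc1ccc(F)c(C(F)F)c1)C1CS(=O)(=O)C1`: 0.245 h

Compound 1 has the highest number of the three, and compound 2 and compound 3 both lie beyond the scatter below it. Compound 4 `NS(=O)(=O)CC(=O)NCCSc1nonc1/C(=N/O)Nc1cccc(Br)c1` changes compound 1 in one place: bromo in place of difluoromethyl on an aromatic carbon. This puts bromo in place of difluoromethyl on an aromatic carbon. For the measured compounds named here, no measured step makes this swap. The only one available, a 1.1-fold lower number from compound 2 to compound 3 (0.04 log units; within the scatter), concerns a group on a carbonyl carbon, so it offers little guidance. With no evidence for a shift, no change beyond the scatter is expected in this assay. The expected step is a 1.3-fold lower number from compound 1 to compound 4 (0.10 log units; within the scatter). Compound 4 is estimated at 1.2 h, with an expected range of 0.45 h to 3 h.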

Compound 4, half-life: 0.918 h
For compound 4 the middle estimate is 1.3-fold (0.12 log units) above the measured one; the measured number falls inside the stated range.
By their numbers in this assay, from the lowest: compounds 3 and 2 (each within the scatter of the next); then compounds 4 and 1 (each within the scatter of the next).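

In this assay, bromo in place of difluoromethyl on this aromatic carbon gives a 1.6-fold lower number from compound 1 to compound 4 (0.21 log units; within the scatter), so at this position, in this compound, the swap causes no shift beyond the scatter. For the compounds shown here, the only earlier step concerned a group on a carbonyl carbon, so this is the first direct reading for a change on the aromatic ring. Nothing measured on hand explains this result.

As far as these compounds go, how an amine, a methoxy group or a carboxylic acid would fare on this carbon remains open. So does whether the same swap would behave alike on compound 2 or compound 3.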